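Swapping fluoromethyl for vinyl on the shared core

A few compounds are considered here, and "the series" means these few. Any claim that something is new, unique, unknown or untested is made for them only; others in the source may bear on it.

Compound 1 `CC(C)CCn1c(Cn2c(=O)n(C(C)C)c3ccccc32)nc2cc(C(C)(C)N)ccc21` gives 3270 nM
Compound 2 `CC(C)CCn1c(Cn2c(=O)n(C(C)C)c3ccccc32)nc2cc(CF)ccc21` gives 37300 nM

In an ADME assay on HEp-2 cells (Homo sapiens) for cytotoxicity (a lower number here means that less compound is tolerated, a higher number that more compound is tolerated), compound 2 has the higher of the two numbers, so more of it is tolerated. Compound 3 `C=Cc1ccc2c(c1)nc(Cn1c(=O)n(C(C)C)c3ccccc31)n2CCC(C)C` has vinyl in place of fluoromethyl on an aromatic carbon and is otherwise unchanged. Within the data shown here, the one measured step at that carbon is an 11-fold higher number from compound 1 to compound 2 (1.06 log units; beyond the scatter) and it is large, so this spot can matter. Among the measured compounds shown here, that step involves a different pair of groups, however, and no measured step swaps these two. The expected change is therefore small, with none beyond the scatter, and the estimated step is a 1.2-fold lower number from compound 2 to compound 3 (0.09 log units; within the scatter) for now. Compound 3 is expected at 30000 nM with 12000 nM to 70000 nM as the estimated range.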

Compound 3, half-maximal cytotoxic concentration: 6520 nM
The estimate for compound 3 lay 4.6-fold (0.66 log units) above the measured number, outside the stated range (below it).
By their numbers in this assay, from the lowest: compounds 1 and 3 (each within the scatter of the next); then compound 2.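

In this assay this aromatic carbon responds even to a swap between two groups of 2 heavy atoms each, giving a 5.7-fold lower number from compound 2 to compound 3 (0.76 log units; beyond the scatter) in this comparison. Vinyl carries no amine, yet a 2.0-fold higher number from compound 1 to compound 3 (0.30 log units; within the scatter) shows that it stays close to 1-amino-1-methylethyl, so among these three compounds only fluoromethyl stands apart. Nothing available explains why these groups differ.

Going by these compounds, it remains open whether the higher number follows fluorine itself or the group as a whole. Methyl, difluoromethyl or trifluoromethyl at this carbon could separate those readings.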